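From 3,4-dimethylphenyl to 3,4-difluorophenyl on the shared core

The source may hold more compounds than are shown below. What is called first, only, known or untested is meant among the compounds shown, and "the series" means these compounds.

Compound 1 `CCc1ccc(C[C@H]2COC(=O)[C@@H]2Cc2ccc(Cl)c(Cl)c2)cc1` with 16000 nM 
Compound 2 `Cc1ccc(C[C@H]2COC(=O)[C@@H]2Cc2ccc(Cl)c(Cl)c2)cc1C` with 16000 nM 

Both values come from a functional assay on HL-60 cells (Homo sapiens) for cytotoxicity, read by WST assay, with a stated time of 48 h (on this read-out lower numbers stand for an effect already at smaller amounts and higher numbers for an effect only at larger amounts of compound), and on them compound 2 stands level with compound 1. The next compound is compound 3 `O=C1OC[C@H](Cc2ccc(F)c(F)c2)[C@H]1Cc1ccc(Cl)c(Cl)c1` which keeps the shared core and differs from compound 2 at one place (3,4-difluorophenyl in place of 3,4-dimethylphenyl on a saturated chain carbon bound to a saturated ring carbon). There, 3,4-difluorophenyl stands in place of 3,4-dimethylphenyl on a saturated chain carbon bound to a saturated ring carbon. Within the data shown here, only one measured step bears on this place: 3,4-dimethylphenyl in place of 4-ethylphenyl gave no change at the digits printed from compound 1 to compound 2 (within the scatter) and so no shift beyond the scatter. Among the measured compounds shown here, no measured compound carries 3,4-difluorophenyl, so that single step is thin evidence. In this assay the expected result is a 1.1-fold higher number from compound 2 to compound 3 (0.05 log units; within the scatter) with no step beyond the scatter and no favoured direction. For compound 3 the estimated value is 18000 nM within a range from 8000 nM to 40000 nM as the expected span.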

Compound 3, half-maximal effective concentration: 25000 nM
Compound 3: the middle estimate sits 1.4-fold (0.14 log units) below what was measured; the measured number falls inside the stated range.
By their numbers in this assay, from the lowest: compounds 1, 2 and 3 (each within the scatter of the next).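

In this assay, 3,4-difluorophenyl on a saturated chain carbon bound to a saturated ring carbon gives a 1.6-fold higher number from compound 2 to compound 3 (0.19 log units; within the scatter) and a 1.6-fold higher number from compound 1 to compound 3 (0.19 log units; within the scatter). Among these compounds, compound 3 is the first of the series with fluorine on this phenyl ring, whereas compounds 1 and 2 carry only carbon groups there, and this exchange gives no step beyond the scatter from either of them. Nothing measured here gives a reason for this result.

From the compounds shown here alone, all three compounds carry a phenyl ring at this place, so the effect of an amine or a carboxylic acid on that ring remains open, as does that of a longer chain in place of the ethyl group of compound 1. Going by these compounds, it is also open whether steps at this place would stay this small if the rest of the shared core carried different groups.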